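The compounds below may be only part of what the source reports. "The series", "measured", "known", "first", "only" and "open" are said of these compounds alone.

Compound 1 `CCCc1cc2ccccc2nc1-c1cc(-c2ccc(C)cc2)no1` gives only a limit in a functional assay on A549 cells (Homo sapiens) for inhibition, read by MTT assay, with a stated time of 24 h (a higher number here means a weaker inhibitor, a lower number a stronger inhibitor), namely > 100000 nM. Compound 2 `CCCCc1cc2ccccc2nc1-c1cc(-c2ccc(C)cc2)no1` likewise reaches only a limit, > 100000 nM. Compound 3 `CCCCCc1cc2ccccc2nc1-c1cc(-c2ccc(C)cc2)no1` also stops at a limit, > 100000 nM.

Compound 1 therefore stands at a limit, not at a number, and the same holds for the two others; this is the limit of > 100000 nM in this assay, at which 3 of the 3 values shown sit. The steps a step that the two limits leave unreadable from compound 1 to compound 2, a step that the two limits leave unreadable from compound 1 to compound 3 and a step that the two limits leave unreadable from compound 2 to compound 3 are unreadable for that reason. Compound 4 `CCCc1cc2ccccc2nc1-c1cc(-c2ccc(C(F)(F)F)cc2)no1` differs from compound 1 by trifluoromethyl in place of methyl on an aromatic carbon. For the measured compounds named here, no measured step bears on this change; all three chain lengthenings stayed at the limit. Compound 4 is expected to sit at or near that limit too, with an estimated step of a number no higher from compound 1 to compound 4 (the limit leaves the size open) and an estimated value of 100000 nM, ranging from 30000 nM to 300000 nM.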

Compound 4, half-maximal inhibitory concentration: 43900 nM
Estimate against measurement, compound 4: 2.3-fold (0.36 log units) above; the measured number falls inside the stated range.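

Trifluoromethyl in place of methyl, on an aromatic carbon para to a large group, gives an at least 2.2-fold lower number from compound 1 to compound 4 (0.35 log units; beyond the scatter) in this assay. This is the first change shown that brings a compound off the limit, and so the first sign that the number responds to a change at this position: the limit of > 100000 nM in this assay, at which 3 of the 4 values shown sit.

Going by these compounds, the full size of the step stays open, as compound 1 has only a limit. Also open, on these data alone, is how a chlorine atom, a methoxy group or a nitrile would behave at this position, and whether trifluoromethyl would lower the number with the longer chains of compound 2 and compound 3.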